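Swapping the pyrazole of compound 1 for an isoxazole

A few compounds are considered here, and "the series" means these few. Any claim that something is new, unique, unknown or untested is made for them only; others in the source may bear on it.

Measured compounds:
- compound 1 `CC(C)Oc1ccc(-c2nnc(-c3ccnn3C)s2)cc1Cl`: 7.04
- compound 2 `CC(C)Oc1ccc(-c2nnc(-n3cc4c(n3)CCN(CCC(=O)O)C4)s2)cc1C#N`: 2.58
- compound 3 `Cc1nn(-c2nnc(-c3ccc(OC(C)C)c(Cl)c3)s2)c(C)c1CCC(=O)O`: 4.3

In a physicochemical assay for lipophilicity, at pH 7.4 (on this read-out higher numbers stand for higher lipophilicity and lower numbers for lower lipophilicity), compound 1 gives the highest of the three numbers. Compound 3 sits lower by a gap beyond the usual scatter, and compound 2 lies lower still, again beyond the scatter. Compound 4 `CC(C)Oc1ccc(-c2nnc(-c3ccno3)s2)cc1Cl` has not yet been measured. It differs from compound 1 in one place: 1,2-oxazol-5-yl in place of 1-methyl-1H-pyrazol-5-yl on an aromatic carbon. For the measured compounds named here, no pair of measured compounds shows this single change, so the size of the step is not known from the data. A small decrease in this assay is expected, of about a number 0.44 log units lower from compound 1 to compound 4 (beyond the scatter), not far beyond the scatter. For compound 4 the value in this assay is estimated at 6.6, between 5.9 and 7.2.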

Compound 4, distribution coefficient: 6.93
For compound 4 the middle estimate is 0.33 log units below the measured one, within the range that was stated.
By their numbers in this assay, from the lowest: compound 2; then compound 3; then compounds 4 and 1 (each within the scatter of the next).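

In this assay, putting 1,2-oxazol-5-yl in place of 1-methyl-1H-pyrazol-5-yl on this aromatic carbon gives a number 0.11 log units lower from compound 1 to compound 4 (within the scatter) and so leaves the two compounds indistinguishable on this read-out. For the compounds shown here, this is the first single-place change available here, and it shows that one five-membered aromatic ring with two hetero atoms can replace the other at this position without a measurable shift. No supporting data are available to explain this result.

From the compounds shown here alone, whether a phenyl ring or a butyl chain on this carbon would also leave the number in place remains open.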